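The source may hold more compounds than are shown below. What is called first, only, known or untested is meant among the compounds shown, and "the series" means these compounds.

Working notes on the series. In a functional assay on HCT-116 cells (Homo sapiens) for antiproliferative activity, read by MTT assay, with a stated time of 72 h (on this read-out higher numbers stand for weaker inhibition and lower numbers for stronger inhibition), compound 1 (`COc1ncc(-c2ccc3c(c2)NC(=O)CO3)cc1NS(=O)(=O)c1ccc(F)cc1`) gives 24900 nM and compound 2 (`CC(C)N1C(=O)COc2ccc(-c3cccc(NS(=O)(=O)c4ccc(F)cc4)c3)cc21`) gives 22600 nM. These two values lie within the scatter of each other, so compound 2 stands level with compound 1, and both sit in the same weak range of the read-out.

The next compound to be read is compound 3 (`COc1ccc(N2C(=O)COc3ccc(-c4cccc(NS(=O)(=O)c5ccc(F)cc5)c4)cc32)cc1`). It keeps the rest of compound 2 and carries 4-methoxyphenyl in place of isopropyl on an amide-type nitrogen in a ring, the six-membered non-aromatic ring with 1 nitrogen and 1 oxygen: 4-methoxyphenyl in place of isopropyl on an amide-type nitrogen in a ring. The change adds an aromatic ring of carbon only and one hydrogen-bond acceptor at that nitrogen.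

Going by the values given here, no measured pair isolates a change on this nitrogen, so the data give no direct guide to its size. The expectation rests on compound 2 at 22600 nM as the starting point. In this assay, no step beyond the scatter is expected, with only a slight lean toward a lower number, an estimated 1.5-fold lower number from compound 2 to compound 3 (0.18 log units; within the scatter). For compound 3 the estimated value is 15000 nM, with an expected range from 5000 nM to 45000 nM.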

Compound 3, half-maximal inhibitory concentration: 28300 nM
For compound 3 the middle estimate is 1.9-fold (0.28 log units) below the measured one; the measured number falls inside the stated range.
By their numbers in this assay, from the lowest: compounds 2, 1 and 3 (each within the scatter of the next).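

In this assay the amide-type nitrogen in the six-membered non-aromatic ring with 1 nitrogen and 1 oxygen now has its first pair of compounds differing in one place: 4-methoxyphenyl in place of isopropyl gives a 1.3-fold higher number from compound 2 to compound 3 (0.10 log units; within the scatter) and so stands level with isopropyl. An entering group of 8 heavy atoms, with one six-membered aromatic ring of carbon only and 1 hydrogen-bond acceptor, therefore gives no step beyond the scatter against a leaving group of 3 heavy atoms with no ring, which shows that this particular exchange at this nitrogen leaves the read-out unmoved. No measurement at hand offers a reason for this flat result.

Going by these compounds, both groups compared at this nitrogen carry no net charge, so it remains open whether an amine, a carboxylic acid or a longer chain in the same place would give a step beyond the scatter. This single step also says nothing about changes elsewhere on the shared core, where a group such as a nitrile or a trifluoromethyl could behave differently.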